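The source may hold more compounds than are shown below. What is called first, only, known or untested is meant among the compounds shown, and "the series" means these compounds.

In a functional assay on T47D cells (Homo sapiens) for inhibition, read by sulforhodamine B assay, with a stated time of 48 h, tested at 10 uM (on this read-out higher numbers stand for more inhibition at the one concentration tested (going by the name of the read-out) and lower numbers for less inhibition), three compounds built on one shared core have been measured. Compound 1 `COc1ccc(-c2cn3ccnc3c(-c3ccc4ncn(C5CCCCC5)c4c3)n2)cc1` gives -8.6%, compound 2 `c1ccc2c(-c3cn4ccnc4c(-c4ccc5ncn(C6CCCCC6)c5c4)n3)cccc2c1` gives 41.3%, and compound 3 `Fc1ccc(-c2cn3ccnc3c(-c3ccc4ncn(C5CCCCC5)c4c3)n2)cc1` gives 33.3%. Compound 3 thus stands second highest of the three numbers, though its gap to compound 2 lies within the scatter, while its gap to compound 1 lies well beyond it. Compound 4 `c1cn2cc(-c3ccsc3)nc(-c3ccc4ncn(C5CCCCC5)c4c3)c2n1` has not yet been measured. It differs from compound 3 in one place: thiophen-3-yl in place of 4-fluorophenyl on an aromatic carbon. Within the data shown here, two measured steps concern the same position. One is a number 41.9 percentage points higher from compound 1 to compound 3 (beyond the scatter), a large rise; the other is a number 8 percentage points lower from compound 2 to compound 3 (within the scatter), within the scatter. Among the measured compounds shown here, exchanging the group at this position has therefore moved the read-out in this assay strongly once and hardly at all once, and no measured compound carries a thiophen-3-yl there. A step of moderate size in either direction, or none beyond the scatter, is expected; the estimated step is a number 3.3 percentage points lower from compound 3 to compound 4 (within the scatter). For compound 4 a value of 30% is expected, with a range from 5% to 55%.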

Compound 4, a percentage reported as inhibition, at one concentration (the size of the read-out at that concentration, not a potency): 63.7%
For compound 4 the middle estimate is 33.7 percentage points below the measured one; measured number outside the range, above it.
By their numbers in this assay, from the lowest: compound 1; then compounds 3 and 2 (each within the scatter of the next); then compound 4.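

In this assay the shared core reaches a clearly higher level than any earlier compound showed: the number is a number 30.4 percentage points higher from compound 3 to compound 4 (beyond the scatter) and a number 22.4 percentage points higher from compound 2 to compound 4 (beyond the scatter) and also a number 72.3 percentage points higher from compound 1 to compound 4 (beyond the scatter) when thiophen-3-yl sits on this aromatic carbon. The position therefore accepts a five-membered aromatic ring with one sulfur atom, and among the four groups shown this one gives the highest number, above 4-fluorophenyl, naphthalen-1-yl and 4-methoxyphenyl. Nothing available explains this rise.

As far as these compounds go, it remains open whether the gain belongs to thiophen-3-yl alone or extends to related rings such as thiophen-2-yl, furan-3-yl or pyridin-3-yl. A single concentration also cannot show how potent compound 4 is, and groups of another kind at this position, such as an amine or a carboxylic acid, remain untested in the compounds shown here.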